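A few compounds are considered here, and "the series" means these few. Any claim that something is new, unique, unknown or untested is made for them only; others in the source may bear on it.

Working notes on the series in an assay on HepG2 cells for agonist activity at nuclear receptor subfamily 1 group I member 3 (Homo sapiens), read by a luciferase reporter, with a stated time of 23 h; on this read-out lower numbers stand for an effect already at smaller amounts and higher numbers for an effect only at larger amounts of compound. For the measured compounds named here, compound 1 `N#Cc1ccc(-c2nc3sccn3c2/C=N/OCc2ccc(Cl)c(Cl)c2)cc1` gives 3400 nM and stands as the only entry with a number. Compound 2 `C(=N/OCc1ccc(Oc2ccccc2)cc1)\c1c(-c2ccc3ccccc3c2)nc2occn12` is recorded as "not active" (no number reported), without a number. Compound 3 `Cc1ccc(-c2nc3sccn3c2/C=N/OCc2ccc(Cl)c(Cl)c2)cc1` differs from compound 1 in one place: methyl in place of cyano on an aromatic carbon. Going by the values given here, no step between two measured compounds is available, so the weight of this change in this assay has not been seen. The step expected here, a 1.3-fold higher number from compound 1 to compound 3 (0.12 log units; within the scatter), is modest, towards an effect only at larger amounts, and may well fall within the scatter. Compound 3 is estimated at 4500 nM, with a range from 1500 nM to 14000 nM.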

Compound 3, half-maximal effective concentration: 490 nM
Compound 3: middle estimate off by 9.2-fold (0.96 log units), on the high side; the measured number lies below the stated range.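

In this assay, methyl in place of cyano on this aromatic carbon, para to a large group, gives a 6.9-fold lower number from compound 1 to compound 3 (0.84 log units; beyond the scatter), so the read-out responds to the group held at this position. For the compounds shown here, this is the first step that can be read, and it shows that one change here, with the rest of the structure kept, is enough to move the number beyond the scatter. Nothing measured on these compounds accounts for the step.

As far as these compounds go, whether methoxy, chloro or an amine at this position would follow methyl or cyano remains open. From the compounds shown here alone, it is also open whether the step would hold with the dichlorobenzyl part or the shared core replaced.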